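Replacing (ethoxycarbonyl)amino with 3-hydroxypropyl in compound 3

The compounds below may be only part of what the source reports. "The series", "measured", "known", "first", "only" and "open" are said of these compounds alone.

Of the compounds shown here, three have so far been measured in an ADME assay on MRC5 cells (Homo sapiens) for cytotoxicity, read by fluorescence and resazurin assay, with a stated time of 3 days (on this read-out lower numbers stand for an effect already at smaller amounts and higher numbers for an effect only at larger amounts of compound), to date. Compound 1 (`C#CC1(O)C=CC(=O)C=C1`) gives 2100 nM as its value, and compound 2 (`COC1(c2nc3ccccc3s2)C=CC(=O)C=C1`) gives 1100 nM as its value. Compound 3 (`CCOC(=O)Nc1ccc(S(=O)(=O)n2c(C3(O)C=CC(=O)C=C3)cc3ccccc32)cc1`) gives 86 nM in the same read-out, the lowest of the three numbers and beyond the scatter from both of the others.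

The next compound, compound 4 (`O=C1C=CC(O)(c2cc3ccccc3n2S(=O)(=O)c2ccc(CCCO)cc2)C=C1`), carries 3-hydroxypropyl in place of (ethoxycarbonyl)amino on an aromatic carbon, para to a large group (3-hydroxypropyl in place of (ethoxycarbonyl)amino on an aromatic carbon), and otherwise matches compound 3. Going by the values given here, no measured pair shows a change of this kind, so the size of the step in this assay can only be judged loosely. Compound 3, at 86 nM as its value, is the only close reference, and compound 4 is expected to stay near it. A small move toward a higher number is expected (a 1.7-fold higher number from compound 3 to compound 4 (0.24 log units; within the scatter)), possibly no larger than the scatter. For compound 4 the estimated value is 150 nM (expected range 50 nM to 450 nM).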

Compound 4, half-maximal effective concentration: 51 nM
The estimate for compound 4 lay 2.9-fold (0.47 log units) above the measured number; low and high end bracket the measured number.
By their numbers in this assay, from the lowest: compounds 4 and 3 (each within the scatter of the next); then compounds 2 and 1 (each within the scatter of the next).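

In this assay, the exchange gives a 1.7-fold lower number from compound 3 to compound 4 (0.23 log units; within the scatter), so this pair does not separate the two groups. On this aromatic carbon, para to a large group, the read-out stays at the same level without the nitrogen and the double bond of (ethoxycarbonyl)amino, and this holds for this one pair only. Nothing shown gives a reason why the two groups read alike.

The compounds shown leave open whether a group of another kind at this place, such as an amine, a carboxylic acid or a chain longer than 3-hydroxypropyl, would also stay at this level. They also leave open whether plain hydrogen there would do the same, and so whether the substituent at this place matters to the read-out at all.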